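Swapping Morpholine for Piperidine on the Ring Nitrogen Substituent

A few compounds are considered here, and "the series" means these few. Any claim that something is new, unique, unknown or untested is made for them only; others in the source may bear on it.

Two compounds have been measured in a functional assay on PC-3 cells (Homo sapiens) for inhibition, read by MTT assay, with a stated time of 48 h; on this read-out higher numbers stand for weaker inhibition and lower numbers for stronger inhibition:
- compound 1 `COc1cc(-c2nc3cc(/C=C4\SC(=O)NC4=O)ccc3[nH]2)cc(OC)c1OC` gives 12000 nM
- compound 2 `COc1cc(-c2nc3cc(/C=C4\SC(=O)N(CC(=O)N5CCOCC5)C4=O)ccc3[nH]2)cc(OC)c1OC` gives 5940 nM

Going by the values given here, compound 2 holds the lowest of the two numbers; its nearest neighbour is compound 1, and the one measured step, a 2.0-fold lower number from compound 1 to compound 2 (0.31 log units; beyond the scatter), came from putting ((morpholin-4-yl)carbonyl)methyl in place of hydrogen on an amide-type nitrogen in a ring.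

Compound 3 `COc1cc(-c2nc3cc(/C=C4\SC(=O)N(CC(=O)N5CCCCC5)C4=O)ccc3[nH]2)cc(OC)c1OC` keeps everything in compound 2 except one change: piperidin-1-yl in place of morpholin-4-yl on a carbonyl carbon. Among the compounds with values here, no measured step touches this kind of swap, so the only guide is that compound 2 and compound 1 differ by a modest amount despite a much larger structural change than the one proposed here. On that basis the step from compound 2 to compound 3 in this assay is expected to stay within the scatter, in no clear direction, a 1.1-fold lower number from compound 2 to compound 3 (0.03 log units; within the scatter). Compound 3 is therefore estimated at 5500 nM, with a plausible range from 2200 nM to 14000 nM.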

Compound 3, half-maximal inhibitory concentration: 14700 nM
Beside the measured number, compound 3's estimate is 2.7-fold (0.43 log units) below it; the whole stated range lies below it.
By their numbers in this assay, from the lowest: compound 2; then compounds 1 and 3 (each within the scatter of the next).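

In this assay, this position responds to what sits on the carbonyl carbon, not only to whether the amide-type nitrogen carries a substituent: exchanging morpholin-4-yl for piperidin-1-yl, which puts a carbon where the ring oxygen stood and leaves the ring size unchanged, gives a clear shift (a 2.5-fold higher number from compound 2 to compound 3 (0.39 log units; beyond the scatter)). Compound 1 had shown only that one arm on this nitrogen lowered the number, whereas ((piperidin-1-yl)carbonyl)methyl in place of hydrogen leaves no difference that can be told from the scatter (a 1.2-fold higher number from compound 1 to compound 3 (0.09 log units; within the scatter)), so among these three compounds the lower number belongs to compound 2 alone and not to this kind of arm in general. Going by these compounds alone, no measurement here bears on why the single ring atom changes the result.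

As far as these compounds go, whether the ring oxygen itself is what counts stays open, and a piperazin-1-yl ring, with a second nitrogen in that place, or an open-chain dimethylamino group on the same carbonyl carbon would help to separate the possibilities. A longer chain between the carbonyl and the ring nitrogen, carrying the same morpholin-4-yl group, would show whether the length of the arm matters as well.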